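The compounds below may be only part of what the source reports. "The series", "measured", "known", "first", "only" and "open" are said of these compounds alone.

Working notes on the series. In a functional assay on KB cells (Homo sapiens) for inhibition, read by sulforhodamine B assay, with a stated time of 72 h (a lower number here means a stronger inhibitor of growth, a higher number a weaker inhibitor of growth), compound 1 (`CNC(=O)/C=C/c1ccncc1-c1ccc2cc[nH]c2c1`) gives > 10000 nM, which is a limit of the assay and not a number. In this assay, compound 2 (`CCOC(=O)/C=C/c1ccncc1-c1ccc2[nH]ccc2c1`) gives > 10000 nM, again a limit and not a number. Compound 2 therefore has no measured number, and its standing rests on that limit alone. The data so far come to the limit of > 10000 nM in this assay, at which 2 of the 2 values shown sit.

Compound 3 (`CCOC(=O)/C=C/c1ccncc1-c1ccc2c(ccn2C)c1`) differs from compound 2 in one place: methyl in place of hydrogen on an aromatic nitrogen. Going by the values given here, no step between measured compounds is available to size this change. With nothing yet measured below the limit, the expectation in this assay is no step beyond the scatter, and a reading at the limit is the most likely outcome. The estimated step is a number no higher from compound 2 to compound 3 (the limit leaves the size open), a figure that is expected to be rough. The estimate for compound 3 is 10000 nM, with an expected range of 3000 nM to 30000 nM.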

Compound 3, concentration for 50% growth inhibition: 6250 nM
For compound 3 the middle estimate is 1.6-fold (0.20 log units) above the measured one; the measured number falls inside the stated range.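

Methyl in place of hydrogen on the aromatic nitrogen gives the first reading in the series that is a number and not a limit: in this assay compound 3 gives 6250 nM. Compound 2, which carries hydrogen at this place, gives > 10000 nM, a limit and not a number. The change can therefore be read only as a floor, an at least 1.6-fold lower number from compound 2 to compound 3 (0.20 log units; that floor lies within the scatter), so this position accepts a methyl without the reading staying at the limit, but neither the size of the step nor a real gain is settled, and the series as a whole still sits mainly at the limit: the limit of > 10000 nM in this assay, at which 2 of the 3 values shown sit.

On these data alone, whether a longer chain such as propyl or a benzyl group on the same nitrogen would move the number further in this assay remains open. Also open is whether the methyl would give a number when the ester of compound 3 is replaced by a carboxylic acid, and no compound shown tells how far a reading in this series can fall.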